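The source may report more compounds than this note shows. Statements on the series, on what has been measured and on what is new or still open speak of the compounds shown alone.

Series values in a functional assay on MCF7 cells (Homo sapiens) for cytotoxicity, read by MTT assay, with a stated time of 48 h; a higher number here means a weaker inhibitor, a lower number a stronger inhibitor:
- compound 1 `C/C(=N\NC(=S)Nc1ccc(Cl)cc1)c1ccccn1`: 8.49 nM
- compound 2 `C/C(=N\NC(=S)Nc1ccccc1F)c1ccccn1`: 0.39 nM

Compound 2 gives 0.39 nM, the lower of the two numbers and so the stronger inhibitor of the pair. Compound 1 gives 8.49 nM, and this gap lies beyond the scatter of repeated measurements.

The next entry is compound 3 `C/C(=N\NC(=S)Nc1ccccc1)c1ccccn1`, which has hydrogen in place of fluoro on an aromatic carbon of compound 2: hydrogen in place of fluoro on an aromatic carbon.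

For the measured compounds named here, no measured pair differs in one place only, so no measured step guides this change. The two values show only how wide the series is so far. With compound 2 at 0.39 nM, the low end of that span, a moderate shift toward a higher number and weaker inhibition in this assay is expected, though a result within the scatter would not surprise. The expected step is a 5.1-fold higher number from compound 2 to compound 3 (0.71 log units; beyond the scatter). For compound 3 the estimated value is 2 nM, with an expected range of 0.35 nM to 12 nM.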

Compound 3, half-maximal inhibitory concentration: 0.18 nM
Beside the measured number, compound 3's estimate is 11-fold (1.05 log units) above it; measured number below the stated range.
By their numbers in this assay, from the lowest: compound 3; then compound 2; then compound 1.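

In this assay, hydrogen in place of the fluoro group ortho to a large group moves the series in the direction of stronger inhibition (a 2.2-fold lower number from compound 2 to compound 3 (0.34 log units; beyond the scatter)), so at this place the halogen is not required for a low number, and compound 3 now marks the low end of the series. Hydrogen in place of chloro on an aromatic carbon gives a much larger step in the same direction (a 47-fold lower number from compound 1 to compound 3 (1.67 log units; beyond the scatter)), so both halogen-bearing compounds give higher numbers than the compound with hydrogen, and neither compound 1 nor compound 2 goes against this within the three compounds shown. No supporting measurement on hand accounts for either step.

The compounds shown leave open how groups other than hydrogen and the two halogens would behave on this aromatic ring, for instance a methoxy group, an amine or a carboxylic acid, and whether any of them would give a number lower than that of compound 3. Compound 1 and compound 2 also differ in both halogen and place, so the separate contributions of halogen identity and of place on the ring remain unresolved.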